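Dimethylamino in place of amino: working notes on the series

This account rests on a few compounds, and the source may have more. Where it says the series, first, only, none or still open, it means among the compounds named here.

Within the data shown here, in a functional assay on A549 cells (Homo sapiens) for antiproliferative activity, read by MTT assay, with a stated time of 48 h (on this read-out lower numbers stand for stronger inhibition and higher numbers for weaker inhibition), compound 1 (`COc1ccc(C(=O)c2ccc3c(c2)C=CC(C)(C)O3)c(NC(=O)CN)c1`) gives 310 nM, the lower of the two numbers available so far. The other measured member, compound 2 (`COc1ccc(C(=O)c2ccc(OC)c3c2OC(C)(C)C=C3)c(NC(=O)CN(C)C)c1`), gives 890 nM, higher by more than the scatter. The step under consideration leads to compound 3 (`COc1ccc(C(=O)c2ccc3c(c2)C=CC(C)(C)O3)c(NC(=O)CN(C)C)c1`): dimethylamino in place of amino on a saturated chain carbon bound to a carbonyl carbon, with dimethylamino in place of amino on a saturated chain carbon bound to a carbonyl carbon. Among the measured compounds shown here, no measured pair isolates this change, so any judgement of its size in this assay remains loose. For the measured compounds named here, the sole hint is compound 2 at 890 nM, which also carries dimethylamino and favours a higher number over a lower one. A modest rise, probably not beyond the scatter, is expected, with a 1.5-fold higher number from compound 1 to compound 3 (0.19 log units; within the scatter) as the estimated step. For compound 3 the estimated value is 480 nM, with an expected range of 160 nM to 1400 nM.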

Compound 3, half-maximal inhibitory concentration: 1160 nM
The estimate for compound 3 lay 2.4-fold (0.38 log units) below the measured number; the range from low to high includes it.
By their numbers in this assay, from the lowest: compound 1; then compounds 2 and 3 (each within the scatter of the next).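

Dimethylamino in place of amino on a saturated chain carbon bound to a carbonyl carbon now has a direct reading in this assay, with a 3.7-fold higher number from compound 1 to compound 3 (0.57 log units; beyond the scatter) on an otherwise unchanged core. Among these compounds, this gives the change a direction and a size beyond the scatter, which the earlier compounds could only hint at, but it rests on this single pair. No measurement accompanying these compounds offers an explanation for the rise.

As far as these compounds go, it remains open whether the higher number follows from replacing the amide-side amino group's hydrogens with two methyl groups together or whether one methyl group is enough, a question that methylamino at the same place would address. A ring amine such as pyrrolidine, or a longer chain carrying the amino group, would show how far this position tolerates further change.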